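This account rests on a few compounds, and the source may have more. Where it says the series, first, only, none or still open, it means among the compounds named here.

Compound 1 `CCCS(=O)(=O)N1CC=C(c2ccc3c(c2)CC(C2CCN(c4ncc(C5CC5)cn4)CC2)O3)CC1`: 3%
Compound 2 `CCCc1cnc(N2CCC(C3Cc4cc(C5=CCN(S(=O)(=O)CCC)CC5)ccc4O3)CC2)nc1`: 58%

Both compounds were tested in an ADME assay (liver, Mus musculus) for metabolic stability, using microsomes, with a stated time of 10 min; on this read-out higher numbers stand for a more stable compound and lower numbers for a less stable compound. Within the data shown here, compound 2 holds the higher of the two numbers, and the only measured step, a number 55 percentage points higher from compound 1 to compound 2 (beyond the scatter), is what separates it from compound 1. Compound 3 `CCCc1cnc(N2CCC(C3Cc4cc(C5CCN(S(=O)(=O)CCC)CC5)ccc4O3)CC2)nc1` has not yet been measured. It differs from compound 2 in one place: a group of 12 heavy atoms (8 carbon, 1 nitrogen, 2 oxygen, 1 sulfur; one six-membered non-aromatic ring with 1 hetero atom) in place of a group of 12 heavy atoms (8 carbon, 1 nitrogen, 2 oxygen, 1 sulfur; one six-membered non-aromatic ring with 1 hetero atom), on an aromatic carbon. Among the measured compounds shown here, no measured step concerns a change of this kind; the single step recorded in this assay concerns propyl in place of cyclopropyl on an aromatic carbon and says nothing about the change from compound 2 to compound 3. Compound 3 is therefore expected to stay close to compound 2, with a step of a number 2 percentage points higher from compound 2 to compound 3 (within the scatter) that is not expected to reach beyond the scatter. The estimate for compound 3 in this assay is 60%, within a range from 35% to 85%.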

Compound 3, percent of the compound remaining: 52%
The estimate for compound 3 lay 8 percentage points above the measured number; the measured number falls inside the stated range.
By their numbers in this assay, from the lowest: compound 1; then compounds 3 and 2 (each within the scatter of the next).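

In this assay, among these compounds, the first change at this position, on an aromatic carbon of the fused ring system, gives a number 6 percentage points lower from compound 2 to compound 3 (within the scatter). The 1-(propylsulfonyl)piperidin-4-yl group, with 2 double bonds outside aromatic rings in place of 3 for the group it replaces, therefore reads the same as that group within the scatter, whereas the earlier step concerned only propyl and cyclopropyl at the other end of the molecule. Nothing available explains why the two groups read alike.

Among the compounds shown here, this equivalence has been seen only with propyl on the far aromatic ring, so it remains open whether it would hold with the cyclopropyl of compound 1 . Also open, on these data alone, is how the read-out would respond at this position to a shorter chain such as ethyl on the sulfonyl, or to a carbonyl in place of the sulfonyl.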